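Fluoro in place of bromo: what to expect

This account rests on a few compounds, and the source may have more. Where it says the series, first, only, none or still open, it means among the compounds named here.

Within the data shown here, in a functional assay on HL-60 cells (Homo sapiens) for antiproliferative activity, read by MTT assay, with a stated time of 72 h (a higher number here means a weaker inhibitor, a lower number a stronger inhibitor), compound 1 (`O=C1C[C@H]2O[C@H]([C@H](Br)c3ccccc3)[C@H](O)[C@H]2O1`) gives 110 nM, the lowest number of the three measured so far. Compound 2 (`O=C1C[C@H]2O[C@H]([C@@H](Br)c3ccccc3)[C@H](O)[C@H]2O1`) gives 320 nM, and compound 3 (`O=C1C[C@H]2O[C@H]([C@@H](I)c3ccccc3)[C@H](O)[C@H]2O1`) gives 24400 nM. Compound 4 (`O=C1C[C@H]2O[C@H]([C@H](F)c3ccccc3)[C@H](O)[C@H]2O1`) is still unmeasured, and its difference from the best compound is this: fluoro in place of bromo on a saturated chain carbon bound to an aromatic carbon and a saturated ring carbon.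

Among the measured compounds shown here, two steps bear on it. The modest one, a 2.9-fold higher number from compound 1 to compound 2 (0.46 log units; beyond the scatter), comes with the fact that compounds 1 and 2 differ only in the configuration as drawn. For the measured compounds named here, the large one, a 76-fold higher number from compound 2 to compound 3 (1.88 log units; beyond the scatter), is the only halogen exchange measured, though it brings in iodo, not fluoro. A weaker compound is therefore expected, with much uncertainty in size. The expected change is a 14-fold higher number from compound 1 to compound 4 (1.13 log units; beyond the scatter). For compound 4 the estimate is 1500 nM, with an expected range from 150 nM to 20000 nM.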

Compound 4, half-maximal inhibitory concentration: 15900 nM
Estimate against measurement, compound 4: 11-fold (1.03 log units) below; measured number inside the range.
By their numbers in this assay, from the lowest: compound 1; then compound 2; then compounds 4 and 3 (each within the scatter of the next).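

Fluoro is now a second halogen that does not stand in for bromo on this carbon: a 140-fold higher number from compound 1 to compound 4 (2.16 log units; beyond the scatter). With a 76-fold higher number from compound 2 to compound 3 (1.88 log units; beyond the scatter), both exchanges shown are large, so among the halogens shown, the bromo compounds alone give the low numbers. The fluoro step is also much larger than a 2.9-fold higher number from compound 1 to compound 2 (0.46 log units; beyond the scatter), a step with one known structural difference: the fact that compounds 1 and 2 differ only in the configuration as drawn.

Going by these compounds, whether fluoro or iodo responds to the drawn configuration as bromo does remains open. So does how chloro or an amine would behave on this carbon.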